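This account rests on a few compounds, and the source may have more. Where it says the series, first, only, none or still open, it means among the compounds named here.

Compound 2 `CCn1c(/C=C2/C(=O)Nc3ccc(Cl)cc32)nc2ccccc21` was tested in a functional assay on A549 cells (Homo sapiens) for cytotoxicity, read by MTT assay, with a stated time of 48 h; a higher number here means a weaker inhibitor, a lower number a stronger inhibitor. In this assay compound 2 reaches only a limit, > 50000 nM, which is not a number. Compound 1 `Cn1c(/C=C2/C(=O)Nc3ccc([N+](=O)[O-])cc32)nc2ccccc21` also gives only a limit in this assay, > 50000 nM. Every value shown so far sits at that same limit (the limit of > 50000 nM in this assay, at which 2 of the 2 values shown sit). Compound 3 `CCn1c(/C=C2/C(=O)Nc3ccc([N+](=O)[O-])cc32)nc2ccccc21` differs from compound 2 by nitro in place of chloro on an aromatic carbon. Since both measured compounds sit at the limit, no step beyond the scatter is expected: a step that the limit leaves unreadable from compound 2 to compound 3. Compound 3 is estimated at 60000 nM, ranging from 25000 nM to 200000 nM.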

Compound 3, half-maximal inhibitory concentration: > 50000 nM
Compound 3 gave a limit, no number (the forecaster's own chance of this, stated with the estimate: 85%); the middle value does not contradict the limit.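

Compound 3, like compound 1 and compound 2, gives only a limit and no number, so neither step to compound 3 can be read: the limit of > 50000 nM in this assay, at which 3 of the 3 values shown sit.

Going by these compounds, whether any change to the shared core would give a measurable number in this assay stays open.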